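The source may hold more compounds than are shown below. What is called first, only, known or untested is meant among the compounds shown, and "the series" means these compounds.

Of the compounds shown here, three have been measured in a functional assay on ileum for antagonist activity at histamine H1 receptor (Cavia porcellus); on this read-out higher numbers stand for weaker binding and lower numbers for tighter binding. Compound 1, with the structure `N=C(NCCCc1c[nH]cn1)NCCSC(c1ccccc1)c1ccccn1`, gives 100 nM in this assay. Compound 2, with the structure `Cc1ccc(C(CC/N=C(\N)NCCCc2c[nH]cn2)c2ccccn2)cc1`, gives 148 nM in this assay. Compound 3, with the structure `N=C(NCCCc1c[nH]cn1)NCCC(c1ccc(Cl)cc1)c1ccccn1`, gives 77.6 nM in this assay. The number for compound 3 is the smallest of the three, but its gaps to compound 1 and to compound 2 both lie within the usual scatter of repeated measurements, so the three compounds cannot be told apart on these numbers alone.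

Compound 4, with the structure `N=C(NCCCc1c[nH]cn1)NCCC(c1cccc(C(F)(F)F)c1)c1ccccn1`, has not yet been measured. It differs from compound 3 in one place: 3-(trifluoromethyl)phenyl in place of 4-chlorophenyl on a saturated chain carbon bound to an aromatic carbon and a saturated chain carbon. The shared core and the chain that carries the two rings are unchanged.

Within the data shown here, no pair of measured compounds differs in a single place, so there is no measured step that speaks directly to this change. The three measured compounds carry different groups on the same chain carbon, and their numbers all fall within the scatter of one another, which suggests that this part of the molecule tolerates variation without a large shift in this assay. The step from compound 3 to compound 4 is therefore expected to be small, a 1.3-fold higher number from compound 3 to compound 4 (0.11 log units; within the scatter), with no clear direction beyond the scatter. Compound 4 is estimated to give 100 nM in this assay, within a range from 35 nM to 300 nM.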

Compound 4, dissociation constant: 525 nM
Compound 4: middle estimate off by 5.3-fold (0.72 log units), on the low side, outside the stated range (above it).
By their numbers in this assay, from the lowest: compounds 3, 1 and 2 (each within the scatter of the next); then compound 4.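

Among these compounds, exchanging 4-chlorophenyl for 3-(trifluoromethyl)phenyl on the saturated chain carbon gives a 6.8-fold higher number from compound 3 to compound 4 (0.83 log units; beyond the scatter) in this assay, the only single-place step here and one that lies beyond the scatter. The three earlier compounds sat within the scatter of one another, but they differed in more than one place, so they could not show that this position is sensitive; this step shows that the aromatic ring on this carbon can matter, at least for this exchange. The data offer no measured explanation for why the number rises.

The step also changes two things at once, both which group the ring carries and where it carries it, as the numbers in the two group names show, so the compounds shown cannot separate these two contributions. A 4-(trifluoromethyl)phenyl or a 3-chlorophenyl group on the same carbon would help to separate them, while a methoxy group or a carboxylic acid on that ring would show whether the loss extends beyond these halogen-bearing groups.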